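The compounds below may be only part of what the source reports. "The series", "measured", "known", "first", "only" and "open" are said of these compounds alone.

The measured compounds and their values in a functional assay on C6 cells (Rattus norvegicus) for cytotoxicity, read by MTT assay, with a stated time of 24 h, tested at 100 ug/mL; on this read-out higher numbers stand for a weaker effect at the one concentration tested and lower numbers for a stronger effect:

Compound 1, `Cc1nnc(SCC(=O)N/N=c2/scc(-c3ccc(F)cc3)n2-c2ccccc2)s1`, gives 34.9%.
Compound 2, `COc1ccc(-c2cs/c(=N/NC(=O)CSc3nnc(C)s3)n2-c2ccccc2)cc1`, gives 25.9%.
Compound 3, `COc1ccc(-c2cs/c(=N/NC(=O)CSc3ncccn3)n2-c2ccccc2)cc1`, gives 51.5%.

Compound 3 stands highest of the three in this assay, and its separation from the other two lies beyond the scatter in each case. Its step from compound 2, a number 25.6 percentage points higher from compound 2 to compound 3 (beyond the scatter), goes with a change in the core: pyrimidin-2-yl in place of 5-methyl-1,3,4-thiadiazol-2-yl on a sulfur. Compound 1 and compound 2 share the core of compound 2 and differ by fluoro in place of methoxy on an aromatic carbon, a change that made a number 9 percentage points higher from compound 2 to compound 1 (within the scatter), a step within the scatter.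

Compound 4, `O=C(CSc1ncccn1)N/N=c1/scc(-c2ccc(F)cc2)n1-c1ccccc1`, has not yet been measured in this assay. For the measured compounds named here, it differs from compound 3 by fluoro in place of methoxy on an aromatic carbon, which is the same change, at the same place, as the one from compound 2 to compound 1; compound 4 carries the core of compound 3 rather than that of compound 2. The step from compound 3 to compound 4 is expected to be small, an estimated a number 6.5 percentage points higher from compound 3 to compound 4 (within the scatter), because a number 9 percentage points higher from compound 2 to compound 1 (within the scatter) stayed within the scatter, and that single earlier instance is all the expectation rests on. Compound 4 is accordingly expected to give about 58% in this assay, most likely somewhere between 40% and 76%.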

Compound 4, a percentage reported as activity, at one concentration (the size of the read-out at that concentration, not a potency): 53.4%
Compound 4: middle estimate off by 4.6 percentage points, on the high side; the measured number falls inside the stated range.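

In this assay, fluoro in place of methoxy gave a number 1.9 percentage points higher from compound 3 to compound 4 (within the scatter), and this change carried from one core to the other without a measurable difference: the same change on two cores in this assay, a number 9 percentage points higher (within the scatter) from compound 2 to compound 1 and a number 1.9 percentage points higher (within the scatter) from compound 3 to compound 4, 7.1 percentage points apart, within the scatter of two such steps

The exchange on the sulfur, pyrimidin-2-yl in place of 5-methyl-1,3,4-thiadiazol-2-yl, gave a number 18.5 percentage points higher from compound 1 to compound 4 (beyond the scatter), and it too held up with either aromatic substituent: the same change on two cores in this assay, a number 25.6 percentage points higher (beyond the scatter) from compound 2 to compound 3 and a number 18.5 percentage points higher (beyond the scatter) from compound 1 to compound 4, 7.1 percentage points apart, within the scatter of two such steps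

Across these four compounds, then, the two changes appear to act independently of each other, but this rests on only two pairs for each change at a single concentration, so it does not show that either change would carry to a further core or say why the numbers move as they do.

The compounds shown leave open how other groups on that aromatic carbon, such as chloro, trifluoromethyl or an amine, would compare with fluoro and methoxy. They also leave open what a carboxylic acid or a longer chain would do in place of the two rings on the sulfur.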